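Ring amine acylation in the fused tetracyclic series

The source may report more compounds than this note shows. Statements on the series, on what has been measured and on what is new or still open speak of the compounds shown alone.

Compound 2 `Cc1c2c(n3c1CCN(C)C[C@@H](C)[C@H](C)Nc1cc-3ccc1C(N)=O)CC(C)(C)CC2=O` gives the lowest number of the three measured in a functional assay on U-87MG ATCC cells (Homo sapiens) for antiproliferative activity (a higher number here means a weaker inhibitor, a lower number a stronger inhibitor), at 49 nM. Its nearest neighbour is compound 1 `Cc1c2c(n3c1CCCN[C@@H](C)[C@H](C)Nc1cc-3ccc1C(N)=O)CC(C)(C)CC2=O`, which in this assay gives 61 nM, a gap within the scatter; furthest is compound 3 `Cc1c2c(n3c1CCCN(C(=O)CO)[C@@H](C)[C@H](C)Nc1cc-3ccc1C(N)=O)CC(C)(C)CC2=O`, which in this assay gives 111 nM, a gap beyond the scatter.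

The open question is compound 4 `Cc1c2c(n3c1CCN(C(=O)[C@H](C)O)C[C@@H](C)[C@H](C)Nc1cc-3ccc1C(N)=O)CC(C)(C)CC2=O`, which in this assay is not yet measured. It differs from compound 2 by (1-hydroxyethyl)carbonyl in place of methyl on an amine nitrogen in a ring.

For the measured compounds named here, the one measured step that bears on this is the acylation of the same ring amine in the parent pair: a 1.8-fold higher number from compound 1 to compound 3 (0.26 log units; within the scatter). That change put a (hydroxymethyl)carbonyl on the ring nitrogen and moved the number only within the scatter. Going by the values given here, the step from compound 2 to compound 4 puts a closely related (1-hydroxyethyl)carbonyl on the ring nitrogen, displacing a methyl rather than a hydrogen; no measured pair covers the loss of the methyl itself. The expectation for compound 4 is therefore a small rise in this assay, of about the size seen from compound 1 to compound 3, and possibly no step beyond the scatter: a 1.8-fold higher number from compound 2 to compound 4 (0.26 log units; within the scatter).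

Compound 4 is estimated at 90 nM in this assay, with a range from 40 nM to 200 nM.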

Compound 4, half-maximal inhibitory concentration: 88 nM
The estimate for compound 4 lay 1.0-fold (0.01 log units) above the measured number, within the range that was stated.
By their numbers in this assay, from the lowest: compounds 2, 1, 4 and 3 (each within the scatter of the next, the first and the last beyond it).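

In this assay an amine nitrogen in a ring takes a (1-hydroxyethyl)carbonyl of five heavy atoms, with one hydrogen-bond donor, two hydrogen-bond acceptors and one defined stereocentre, in place of a methyl of one heavy atom, and the outcome is a 1.8-fold higher number from compound 2 to compound 4 (0.25 log units; within the scatter) and no more. The earlier compounds shown here showed an acyl group on a ring amine only in place of hydrogen, as a 1.8-fold higher number from compound 1 to compound 3 (0.26 log units; within the scatter) records; this result adds a step within the scatter in which the acyl group replaces a methyl, and neither of the two acylation steps goes against that reading. No measurement at hand accounts for the size of this step.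

The compounds shown leave open how far this nitrogen accepts other groups, such as a longer acyl chain, an aminoacetyl group or a carboxylic acid. They also leave open how the opposite configuration of the (1-hydroxyethyl)carbonyl stereocentre would read in this assay and whether a plain acetyl group, lacking the hydroxyl, would stay within the scatter.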